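Replacing a Nitrophenyl with a Chloromethylphenyl Group

The source may hold more compounds than are shown below. What is called first, only, known or untested is meant among the compounds shown, and "the series" means these compounds.

Compound 3 `N#CC1=C(N)Oc2c(c3nc4ccccc4nc3c3ccccc23)C12C(=O)N(Cc1cnnn1-c1ccc([N+](=O)[O-])cc1)c1ccccc12` carries a 4-nitrophenyl group on an aromatic nitrogen of the shared core. In an ADME assay on L02 cells (Homo sapiens) for antiproliferative activity, read by MTT assay, with a stated time of 48 h (on this read-out lower numbers stand for stronger inhibition and higher numbers for weaker inhibition), compound 3 reaches only the limit of the assay, > 50000 nM, so no number is known for it. Its relatives set the frame. Compound 1 `N#CC1=C(N)Oc2c(c3nc4ccccc4nc3c3ccccc23)C12C(=O)N(Cc1cnnn1-c1cccc(Cl)c1)c1ccccc12` bears 3-chlorophenyl at that nitrogen, and in this assay compound 1 gives 35200 nM. Compound 2 `COc1ccc(-n2nncc2CN2C(=O)C3(C(C#N)=C(N)Oc4c3c3nc5ccccc5nc3c3ccccc43)c3ccccc32)cc1` bears 4-methoxyphenyl, and in this assay compound 2 sits at the limit, > 50000 nM. Two of the three values meet (the limit of > 50000 nM in this assay, at which 2 of the 3 values shown sit). The steps of an at least 1.4-fold higher number from compound 1 to compound 2 (0.15 log units; that floor lies within the scatter) and an at least 1.4-fold higher number from compound 1 to compound 3 (0.15 log units; that floor lies within the scatter) are only floors, and the step that the two limits leave unreadable from compound 2 to compound 3 cannot be read at all. Compound 4 `Cc1ccc(-n2nncc2CN2C(=O)C3(C(C#N)=C(N)Oc4c3c3nc5ccccc5nc3c3ccccc43)c3ccccc32)cc1Cl` is the next variant: 3-chloro-4-methylphenyl in place of 4-nitrophenyl on an aromatic nitrogen. Since every measured step stays within the scatter, the step of an at least 1.1-fold lower number from compound 3 to compound 4 (0.04 log units; that floor lies within the scatter) is expected to lie within the scatter as well. Compound 4 is therefore estimated at 45000 nM, within a range from 20000 nM to 100000 nM, with a fair chance that it too reaches only a limit.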

Compound 4, half-maximal inhibitory concentration: > 50000 nM
Compound 4: only a limit was reported; the forecaster's own chance of this, stated with the estimate: 55%; at least 1.1-fold (0.04 log units) between middle value and limit.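

Adding only a methyl to the 3-chlorophenyl group gives an at least 1.4-fold higher number from compound 1 to compound 4 (0.15 log units; that floor lies within the scatter) in this assay, so this small change on the ring shows no step beyond the scatter. The steps that link compound 4 to compound 2 and to compound 3 cannot be read, as each has a limit at both ends. Compound 4 gives only a limit, so a third group on this aromatic nitrogen now ends there, and a single real number remains among the compounds shown: the limit of > 50000 nM in this assay, at which 3 of the 4 values shown sit.

As far as these compounds go, how far apart compounds 2, 3 and 4 truly lie stays open. So does whether a phenyl ring bearing an amine or a carboxylic acid, or a longer chain in place of the phenyl ring, would give a number clearly apart from that of compound 1.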